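The source may hold more compounds than are shown below. What is called first, only, known or untested is meant among the compounds shown, and "the series" means these compounds.

Compound 1 `Cc1ccccc1S(=O)(=O)NC(C1=CC(=O)c2c(O)ccc(O)c2C1=O)C(C)C`: 190 nM
Compound 2 `CC(C)C(NS(=O)(=O)c1ccc(Br)cc1)C1=CC(=O)c2c(O)ccc(O)c2C1=O`: "not determined" (no result reported)
Compound 3 `Cc1ccccc1S(=O)(=O)NC(C)C1=CC(=O)c2c(O)ccc(O)c2C1=O`: 70 nM
Compound 4 `CC(=O)c1ccc(S(=O)(=O)NC(C)C2=CC(=O)c3c(O)ccc(O)c3C2=O)cc1`: not yet measured

In a functional assay on HL-60 cells (Homo sapiens) for cytotoxicity, read by MTT assay (a lower number here means a stronger inhibitor, a higher number a weaker inhibitor), compound 3 gives 70 nM, the lower of the two numbers available, and compound 1 gives 190 nM. Moving on to compound 4 brings one change: 4-acetylphenyl in place of 2-methylphenyl on a sulfonyl sulfur. Within the data shown here, the only measured step, a 2.7-fold lower number from compound 1 to compound 3 (0.43 log units; beyond the scatter), is modest and concerns the saturated chain carbon, not the group on the sulfonyl sulfur. Compound 2 does carry a different group there, but it has no result to compare. With no measured guide at this place, no step beyond the scatter is expected, and the estimated step is a 1.3-fold higher number from compound 3 to compound 4 (0.11 log units; within the scatter). For compound 4 the estimate is 90 nM, with an expected range from 30 nM to 270 nM.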

Compound 4, half-maximal inhibitory concentration: 260 nM
For compound 4 the middle estimate is 2.9-fold (0.46 log units) below the measured one, and the stated range covers the measured number.
By their numbers in this assay, from the lowest: compound 3; then compounds 1 and 4 (each within the scatter of the next).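

The group on the sulfonyl sulfur matters as well as the saturated chain carbon: in this assay the swap of 2-methylphenyl for 4-acetylphenyl gives a 3.7-fold higher number from compound 3 to compound 4 (0.57 log units; beyond the scatter) as a modest step. This place in the molecule therefore responds to what it carries, and 2-methylphenyl holds the lower number of this pair. Nothing available explains the step.

This single swap changes the ring's substituent and its place together, so the two effects cannot be separated. Plain phenyl or 4-methylphenyl on the sulfonyl sulfur would help to separate them, and how an amine or a carboxylic acid there would behave stays open.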